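The compounds below may be only part of what the source reports. "The series", "measured", "known", "first", "only" and "open" are said of these compounds alone.

Of the compounds shown here, two have so far been tested in a functional assay on HEK293 cells for agonist activity at Free fatty acid receptor 1 (Homo sapiens), read by HTRF and inositol phosphate accumulation, with a stated time of 60 min; on this read-out higher numbers stand for an effect only at larger amounts of compound and lower numbers for an effect already at smaller amounts. Compound 1, with the structure `COc1cc(Oc2ncc(C)s2)cc(-c2ccc3c(c2)CC[C@H](CCC(=O)O)O3)c1F`, carries a 2-carboxyethyl chain on the shared core. In this assay compound 1 gives > 10000 nM, which is a limit of the assay and not a measured number. Compound 2, with the structure `COc1cc(OC2CCC2)nc(-c2ccc3c(c2)CC[C@H]([C@@H]2C[C@H]2C(=O)O)O3)c1F`, carries a 2-carboxycyclopropyl group instead. In this assay compound 2 gives > 10000 nM, again a limit rather than a number. Compound 2 thus stands at the limit of > 10000 nM in this assay, at which 2 of the 2 values shown sit, so no ordering of the two compounds can be drawn from them.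

Compound 3, with the structure `COc1cc(OC2CCC2)nc(-c2ccc3c(c2)CC[C@H](CCC(=O)O)O3)c1F`, has not yet been measured. It differs from compound 2 by 2-carboxyethyl in place of 2-carboxycyclopropyl on a saturated ring carbon. Among the compounds with values here, no measured pair shows what this exchange does on its own. Within the data shown here, the only related guide is compound 1, which carries the same 2-carboxyethyl chain and gives > 10000 nM, a limit. The step from compound 2 to compound 3 is therefore expected to be a number no higher from compound 2 to compound 3 (the limit leaves the size open), no change beyond the scatter. Compound 3 is estimated at 10000 nM, within a range from 3000 nM to 30000 nM, and a limit is again likely.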

Compound 3, half-maximal effective concentration: > 10000 nM
Compound 3 ended at the assay's limit; the forecaster's own chance of this, stated with the estimate: 65%; the middle value sits exactly at the limit.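

Compound 3, like compound 2, ends at a limit of the assay and not at a number, so no step from one to the other can be read: the limit of > 10000 nM in this assay, at which 3 of the 3 values shown sit.

The compounds shown leave open whether 2-carboxyethyl or 2-carboxycyclopropyl gives an effect at smaller amounts in this assay, and by how much.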